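Antiproliferative series notes: from compound 2 to compound 3

The source may hold more compounds than are shown below. What is called first, only, known or untested is meant among the compounds shown, and "the series" means these compounds.

Measured in a functional assay on HepG2 cells (Homo sapiens) for antiproliferative activity, with a stated time of 72 h; a lower number here means that less compound is needed, a higher number that more compound is needed for the effect:
- compound 1 `COc1ccc(-c2c(I)c(=O)c3c(OC)cc(OC)cc3n2S(=O)(=O)c2ccc(OC)cc2)cc1`: > 17300 nM (a limit)
- compound 2 `COc1cc(OC)c2c(=O)cc(C(=O)Nc3ccc(N4CCN(C)CC4)cc3)[nH]c2c1`: > 19800 nM (a limit)

Compound 2 stands at a limit and not at a number (> 19800 nM). Among the compounds with values here, the only other compound, compound 1, also gives just a limit (> 17300 nM). Within the data shown here, no step between measured compounds is available, so the series offers no measured size of change.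

Compound 3 `COc1cc(OC)c2c(=O)cc(C(=O)Nc3ccc(-n4cccc4)cc3)[nH]c2c1` has not yet been measured. It carries 1H-pyrrol-1-yl in place of 4-methylpiperazin-1-yl on an aromatic carbon, para to a large group 1H-pyrrol-1-yl in place of 4-methylpiperazin-1-yl on an aromatic carbon and otherwise keeps the structure of compound 2.

In this assay, no step beyond the usual scatter is expected, and neither direction is favoured. The estimated step is small (a step that the limit leaves unreadable from compound 2 to compound 3). Compound 3 is expected near 20000 nM with an estimated range of 6000 nM to 40000 nM and may well return only a limit.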

Compound 3, half-maximal effective concentration: > 77000 nM
Compound 3: only a limit was reported; the forecaster's own chance of this, stated with the estimate: 65%; at least 3.8-fold (0.58 log units) between middle value and limit.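

Compound 2 and compound 3 both stand at limits in this assay, so the step for 1H-pyrrol-1-yl in place of 4-methylpiperazin-1-yl cannot be read. The compounds shown leave open whether any group at this place on the shared core gives a number rather than a limit.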